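A few compounds are considered here, and "the series" means these few. Any claim that something is new, unique, unknown or untested is made for them only; others in the source may bear on it.

Measured compounds:
compound 1, `CC1=CC[C@H](C(C)(C)NC(=S)N/N=C/c2ccc(O)cc2)CC1` — in a functional assay on K562 cells (Homo sapiens) for inhibition, read by sulforhodamine B assay, with a stated time of 48 h (a lower number here means a stronger inhibitor of growth, a higher number a weaker inhibitor of growth), compound 1 gives > 100000 nM, which is a limit of the assay and not a number.
compound 2, `COc1cc(/C=N/NC(=S)NC(C)(C)[C@H]2CC=C(C)CC2)ccc1O` — in this assay compound 2 gives 85200 nM.

The two measured compounds share the core of compound 1 and differ only by a methoxy in place of hydrogen on an aromatic carbon. That step, an at least 1.1-fold lower number from compound 1 to compound 2 (0.06 log units; that floor lies within the scatter), stays within the scatter. Compound 1 itself sits at the limit of > 100000 nM in this assay, at which 1 of the 2 values shown sits, so for compound 1 only a limit is known in this assay, and it stands at the weak end of what has been measured.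

Compound 3, `CC1=CC[C@H](C(C)(C)NC(=S)N/N=C/c2ccc[nH]2)CC1`, is not yet measured. It differs from compound 1 by 1H-pyrrol-2-yl in place of 4-hydroxyphenyl on a carbon with a double bond to nitrogen. No measured step alters that part of the molecule: the single step shown changes a substituent on the retained aromatic ring, not the ring itself, so it bears on the new change only in showing weak growth inhibition across the series. In this assay compound 3 is expected to stay near the limit, estimated at 100000 nM with a range from 40000 nM to 250000 nM. The step expected from compound 1 to compound 3 is a number no higher from compound 1 to compound 3 (the limit leaves the size open), within the scatter, and a limit rather than a number is about as likely as not.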

Compound 3, concentration for total growth inhibition: > 100000 nM
Compound 3: only a limit was reported; the forecaster's own chance of this, stated with the estimate: 55%; the middle value sits exactly at the limit.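

In this assay compound 3 gives > 100000 nM, which is a limit of the assay and not a number. Compound 1 is also known only as a limit, so no step can be read between compound 1 and compound 3: the limit of > 100000 nM in this assay, at which 2 of the 3 values shown sit.

The compounds shown leave open how 1H-pyrrol-2-yl and 4-hydroxyphenyl compare in growth inhibition.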